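Aryl swap on a piperazine linked to a cyclic sulfonamide

The compounds below may be only part of what the source reports. "The series", "measured", "known", "first", "only" and "open" are said of these compounds alone.

Compound 1 `COc1ccccc1N1CCN(CCCCCN2C(=O)c3ccccc3S2(=O)=O)CC1`: 1990 nM
Compound 2 `O=C1c2ccccc2S(=O)(=O)N1CCCCCN1CCN(c2cccc(C(F)(F)F)c2)CC1`: 1350 nM

Both compounds were tested in an assay on HEK293 cells for displacement of a labelled ligand from 5-hydroxytryptamine receptor 6 (Homo sapiens); a higher number here means a weaker inhibitor, a lower number a stronger inhibitor. Compound 2 gives the lowest of the two numbers, and its nearest neighbour is compound 1, whose step a 1.5-fold lower number from compound 1 to compound 2 (0.17 log units; within the scatter) lies within the scatter. Compound 3 `O=C1c2ccccc2S(=O)(=O)N1CCCCCN1CCN(c2cccc3ccccc23)CC1` differs from compound 2 only in that (naphthalen-1-yl in place of 3-(trifluoromethyl)phenyl on an amine nitrogen in a ring). Within the data shown here, the only measured step at this position, a 1.5-fold lower number from compound 1 to compound 2 (0.17 log units; within the scatter), is small, so no step beyond the scatter is expected here either. For compound 3 the estimate is 900 nM, with a range from 300 nM to 3000 nM, a change of a 1.5-fold lower number from compound 2 to compound 3 (0.18 log units; within the scatter) from compound 2.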

Compound 3, inhibition constant: 101 nM
Compound 3: the middle estimate sits 8.9-fold (0.95 log units) above what was measured; measured number outside the range, below it.
By their numbers in this assay, from the lowest: compound 3; then compounds 2 and 1 (each within the scatter of the next).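

In this assay, this position turns out to be able to move the number far: the change gives a 13-fold lower number from compound 2 to compound 3 (1.13 log units; beyond the scatter), and against the 2-methoxyphenyl group it gives a 20-fold lower number from compound 1 to compound 3 (1.29 log units; beyond the scatter). The step from compound 2 keeps the heavy-atom count unchanged while adding a second six-membered aromatic ring of carbon only. No evidence at hand accounts for this gain.

On these data alone, whether the second ring alone carries the gain stays open, as does the effect of its attachment, which a naphthalen-2-yl or quinoline group would test. As far as these compounds go, how a shorter chain would behave with naphthalen-1-yl also remains unknown.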